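The compounds below may be only part of what the source reports. "The series", "measured", "known", "first", "only" and "open" are said of these compounds alone.

For the measured compounds named here, compound 1 `Cc1ccc(/C=C/C(=O)NNC(=O)c2ccc3c(c2)OCCO3)cc1` is the reference point: in a functional assay on cells (Cancer cell lines, Homo sapiens) for inhibition, read by MTT assay, with a stated time of 48 h (on this read-out higher numbers stand for weaker inhibition and lower numbers for stronger inhibition), compound 1 gives 1050 nM, the lowest of the three numbers measured so far. Compound 2 `COc1ccccc1/C=C/C(=O)NNC(=O)c1ccc2c(c1)OCCO2` gives 8060 nM and compound 3 `O=C(/C=C/c1ccccc1F)NNC(=O)c1ccc2c(c1)OCCO2` gives 4510 nM; the steps of a 7.7-fold higher number from compound 1 to compound 2 (0.89 log units; beyond the scatter) and a 4.3-fold higher number from compound 1 to compound 3 (0.63 log units; beyond the scatter) both lie beyond the scatter, while the comparison of compound 2 with compound 3 reads a 1.8-fold lower number from compound 2 to compound 3 (0.25 log units; within the scatter). Compound 4 `COc1ccc(/C=C/C(=O)NNC(=O)c2ccc3c(c2)OCCO3)cc1` remains to be measured. It differs from compound 1 by methoxy in place of methyl on an aromatic carbon. Going by the values given here, only the step from compound 1 to compound 2 brings a methoxy in, and there on another aromatic carbon, so it bears loosely on a methoxy para to a large group. A modest weakening at most is expected, a 1.9-fold higher number from compound 1 to compound 4 (0.28 log units; within the scatter). Compound 4 is expected to give 2000 nM, within 800 nM to 6000 nM.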

Compound 4, half-maximal inhibitory concentration: 930 nM
Estimate against measurement, compound 4: 2.2-fold (0.33 log units) above, within the range that was stated.
By their numbers in this assay, from the lowest: compounds 4 and 1 (each within the scatter of the next); then compounds 3 and 2 (each within the scatter of the next).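

At the aromatic carbon para to a large group, methoxy and methyl cannot be told apart in this assay, with a 1.1-fold lower number from compound 1 to compound 4 (0.05 log units; within the scatter). Placement and group identity on the phenyl ring matter more here, since 4-methoxyphenyl stands clear of 2-methoxyphenyl, with an 8.7-fold lower number from compound 2 to compound 4 (0.94 log units; beyond the scatter), and of 2-fluorophenyl, with a 4.8-fold lower number from compound 3 to compound 4 (0.69 log units; beyond the scatter). No measurement available here accounts for these differences. Open, on these data alone, is whether a hydroxyl, an amine or a longer chain such as ethoxy on this same carbon would stay level with methyl and methoxy.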